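This account rests on a few compounds, and the source may have more. Where it says the series, first, only, none or still open, it means among the compounds named here.

Compound 1 `COc1ccc(-c2cn3ccnc3c(-c3ccc4ncn(C5CCCCC5)c4c3)n2)cc1`: 87.2% in a functional assay on NCI/ADR-RES cells (Homo sapiens) for inhibition, read by sulforhodamine B assay, with a stated time of 48 h, tested at 10 uM; on this read-out higher numbers stand for more inhibition at the one concentration tested (going by the name of the read-out) and lower numbers for less inhibition
Compound 2 `c1ccc2c(-c3cn4ccnc4c(-c4ccc5ncn(C6CCCCC6)c5c4)n3)cccc2c1`: 4.43%
Compound 3 `Cc1cccc(-c2cn3ccnc3c(-c3ccc4ncn(Cc5ccccc5)c4c3)n2)c1`: 12.1%

Compound 3 stands second highest of the three numbers in this assay. Its nearest neighbour is compound 2, whose number lies lower by an amount that is within the scatter, so the two are not distinguishable on these data. Its furthest neighbour is compound 1, whose number lies higher by an amount well beyond the scatter.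

Compound 4 `c1ccc(Cn2cnc3ccc(-c4nc(-c5cccc6ccccc56)cn5ccnc45)cc32)cc1` has not yet been measured. It arises from compound 3 by naphthalen-1-yl in place of 3-methylphenyl on an aromatic carbon. Going by the values given here, one measured step bears on this change: the one from compound 1 to compound 2, in which a naphthalen-1-yl group likewise entered in place of a substituted phenyl group, and which gave a number 82.8 percentage points lower from compound 1 to compound 2 (beyond the scatter). That step started from a high number; compound 3 already sits low, so there is little room for a drop of that size. Compound 2, which also carries naphthalen-1-yl, gives 4.43%, and compound 4 is expected to land in that region. The estimated step is therefore a number 6.1 percentage points lower from compound 3 to compound 4 (within the scatter), a change not expected to exceed the scatter. For compound 4 the estimate is 6%, with a range from -8% to 22%.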

Compound 4, a percentage reported as inhibition, at one concentration (the size of the read-out at that concentration, not a potency): 5.83%
Beside the measured number, compound 4's estimate is 0.2 percentage points above it; the range from low to high includes it.
By their numbers in this assay, from the lowest: compounds 2, 4 and 3 (each within the scatter of the next); then compound 1.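

In this assay, the exchange of 3-methylphenyl for naphthalen-1-yl on the aromatic carbon next to the ring nitrogen gives a number 6.3 percentage points lower from compound 3 to compound 4 (within the scatter), so with benzyl on the aromatic nitrogen this change does not separate the two compounds, unlike the exchange of 4-methoxyphenyl for naphthalen-1-yl, which gave a number 82.8 percentage points lower from compound 1 to compound 2 (beyond the scatter). Going by these compounds alone, the new compound also gives the first reading at the aromatic nitrogen: with naphthalen-1-yl held in place, benzyl in place of cyclohexyl gives a number 1.4 percentage points higher from compound 2 to compound 4 (within the scatter), so on these data the two groups on that nitrogen cannot be told apart in this setting. Nothing available accounts for either result.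

The compounds shown leave open whether benzyl and cyclohexyl would also be indistinguishable with 4-methoxyphenyl on the aromatic carbon, since the one high number so far stands with that pairing alone. They also leave open whether the high number depends on the methoxy group itself, which a 4-hydroxyphenyl or 4-aminophenyl group at the same carbon would test, and how a longer alkyl chain on the aromatic nitrogen would read.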